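The source may report more compounds than this note shows. Statements on the series, on what has been measured and on what is new or still open speak of the compounds shown alone.

In a functional assay on HepG2 cells (Homo sapiens) for cytotoxicity, read by MTT assay, with a stated time of 24 h (a lower number here means a stronger inhibitor, a higher number a weaker inhibitor), compound 2 `CN1C/C(=C\c2ccncc2)C(=O)/C(=C/c2ccccc2F)C1` gives 4600 nM, and compound 1 `CN1C/C(=C\c2cccnc2)C(=O)/C(=C/c2ccccc2C(F)(F)F)C1` gives 2550 nM. For the measured compounds named here, these are the only two measurements so far, and they lie within the usual scatter of each other, so they cannot be ranked. Compound 2 therefore stands level with compound 1 on the evidence available.

The next compound changes one group. Compound 3 `CN1C/C(=C\c2ccncc2)C(=O)/C(=C/c2ccccc2C(F)(F)F)C1` has trifluoromethyl in place of fluoro on an aromatic carbon. Going by the values given here, this group is larger, but no measured pair shows this change on its own, so the data give no direct size for it.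

The nearest guide is compound 1, which also carries a trifluoromethyl group and gives 2550 nM. On that basis, no step beyond the scatter is expected in this assay, with any drift more likely towards the number of compound 1 than away from it. For compound 3 the estimated value is 3200 nM, with an expected range from 1400 nM to 7500 nM. The estimate corresponds to an expected step of a 1.4-fold lower number from compound 2 to compound 3 (0.16 log units; within the scatter).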

Compound 3, half-maximal inhibitory concentration: 3300 nM
Compound 3: middle estimate off by 1.0-fold (0.01 log units), on the low side, within the range that was stated.
By their numbers in this assay, from the lowest: compounds 1, 3 and 2 (each within the scatter of the next).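

In this assay, for the compounds shown here, the change from fluoro to trifluoromethyl on an aromatic carbon, ortho to a large group, can now be read on its own for the first time: it gives a 1.4-fold lower number from compound 2 to compound 3 (0.14 log units; within the scatter), so this position accepts the larger group with no step beyond the scatter in compounds of this kind. The second comparison holds trifluoromethyl fixed and puts pyridin-4-yl in place of pyridin-3-yl on a double-bonded chain carbon bound to a double-bonded ring carbon, giving a 1.3-fold higher number from compound 1 to compound 3 (0.11 log units; within the scatter), so this change also stays inside the scatter. Nothing measured here offers an explanation for either of these small steps.

As far as these compounds go, both changes are modest swaps between closely related groups, so it remains open whether a group of a different kind on that aromatic carbon, such as an amine, a carboxylic acid or a methoxy group, would produce a step beyond the scatter. From the compounds shown here alone, it also remains open whether either result would hold on a different core, or with a longer chain in place of the methyl group on the shared core.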